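The source may report more compounds than this note shows. Statements on the series, on what has been measured and on what is new or still open speak of the compounds shown alone.

Compound 1 `COC(=O)/C=C/c1ccncc1-c1ccc2ccccc2c1` and compound 2 `O=C(O)CCc1ccncc1-c1ccc2ccccc2c1` share the same core and differ only in the side chain. In an assay on a protein complex for inhibition of CDK8/Cyclin C (Homo sapiens), with a stated time of 1 h, tested at 10 uM (on this read-out lower numbers stand for less inhibition and higher numbers for more inhibition at the one concentration tested (going by the name of the read-out)), compound 1 gives 102%, and compound 2 gives 101%. For the measured compounds named here, the single measured step, a number 1 percentage points lower from compound 1 to compound 2 (within the scatter), put 2-carboxyethyl in place of 2-(methoxycarbonyl)ethenyl on an aromatic carbon. Compound 2 therefore stands lowest of the two numbers, yet within the scatter of compound 1.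

Compound 3 `COC(=O)CCc1ccncc1-c1ccc2ccccc2c1` differs from compound 2 by methyl in place of hydrogen on an oxygen next to a carbonyl group. Going by the values given here, no measured pair isolates exactly this change; the one step that bears on it, a number 1 percentage points lower from compound 1 to compound 2 (within the scatter), covers a larger rearrangement of the same side chain and stayed within the scatter. On that basis the expected step of a number 2 percentage points lower from compound 2 to compound 3 (within the scatter) is none beyond the scatter. Compound 3 is estimated to give 99%, with a range from 88% to 106%.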

Compound 3, a percentage reported as inhibition, at one concentration (the size of the read-out at that concentration, not a potency): 98%
For compound 3 the middle estimate is 1 percentage points above the measured one; measured number inside the range.
By their numbers in this assay, from the lowest: compounds 3, 2 and 1 (each within the scatter of the next).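

For the compounds shown here, this pair isolates methyl in place of hydrogen on an oxygen next to a carbonyl group for the first time, and in this assay it gives a number 3 percentage points lower from compound 2 to compound 3 (within the scatter), so the carboxy and methoxycarbonyl forms of this side chain cannot be told apart here. Compound 3 also shares the ester of compound 1, leaving 2-(methoxycarbonyl)ethyl in place of 2-(methoxycarbonyl)ethenyl as the one difference, and that step, a number 4 percentage points lower from compound 1 to compound 3 (within the scatter), does not separate the two chains either. No measurement on hand explains why these side chains read alike.

Going by these compounds, it remains open whether an amine, an amide or a longer chain at this place would read the same way. With a single tested concentration, any difference in potency among these compounds also stays hidden.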